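The source may hold more compounds than are shown below. What is called first, only, known or untested is meant among the compounds shown, and "the series" means these compounds.

Two chalcone-type compounds have been measured in a functional assay on PC-3 cells (Homo sapiens) for inhibition, read by MTT assay, with a stated time of 48 h; on this read-out lower numbers stand for stronger inhibition and higher numbers for weaker inhibition. Compound 1 `O=C(/C=C/c1ccccc1Br)c1ccc[nH]1` gives 44000 nM in this assay, while compound 2 `O=C(/C=C/c1ccccc1Cl)c1ccco1` gives 14000 nM and so stands at the lower of the two numbers, its gap to compound 1 lying beyond the scatter. Compound 3 `O=C(/C=C/c1cc([N+](=O)[O-])ccc1Cl)c1ccco1` has not yet been measured; it differs from compound 2 by nitro in place of hydrogen on an aromatic carbon. For the measured compounds named here, with no measured pair showing this change, the step from a 1.8-fold lower number from compound 2 to compound 3 (0.24 log units; within the scatter) is expected to be a modest lowering, close to the edge of the scatter. Compound 3 is therefore estimated at 8000 nM, with a range from 2500 nM to 30000 nM.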

Compound 3, half-maximal inhibitory concentration: 62000 nM
Compound 3: the middle estimate sits 7.8-fold (0.89 log units) below what was measured; the measured number lies above the stated range.
By their numbers in this assay, from the lowest: compound 2; then compounds 1 and 3 (each within the scatter of the next).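

Nitro in place of hydrogen on this aromatic carbon, para to a chloro group, gives a 4.4-fold higher number from compound 2 to compound 3 (0.65 log units; beyond the scatter) and so weakens inhibition, a step beyond the scatter. For the compounds shown here, this is the only single-place change among the compounds, and it shows that this position on the core of compound 2 does not tolerate nitro without a loss. Nothing given here accounts for that loss.

On these data alone, whether an amine or a methoxy group at the same position would also raise the number stays open. So does whether nitro would have the same effect on the core of compound 1.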